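Mirroring one stereocentre in a urea: an expectation

A few compounds are considered here, and "the series" means these few. Any claim that something is new, unique, unknown or untested is made for them only; others in the source may bear on it.

Two ureas have been measured in an ADME assay on the whole organism with Oryza sativa as the target, tested at 1 uM; a lower number here means a stronger effect, a higher number a weaker effect of the compound at the concentration tested. Compound 1, `CCCc1ccc(NC(=O)N[C@@H](C)c2ccccc2)cc1`, gives 76% in this assay. Compound 2, `C[C@@H](NC(=O)Nc1ccc(C(C)(C)C)cc1)c1ccccc1`, gives 88% in this assay, the higher of the two numbers, and its gap to compound 1 lies beyond the scatter, so compound 2 shows the weaker effect of the pair. Compound 3, `C[C@H](NC(=O)Nc1ccc(C(C)(C)C)cc1)c1ccccc1`, has not yet been measured. It differs from compound 2 only in configuration: the two compounds have the same atoms and bonds and differ only in configuration as drawn: 1 of 1 stereo elements differ; a stereocentre at a saturated chain carbon is drawn R in compound 2 and S in compound 3. Going by the values given here, no step between measured compounds in this set shows what such a change of configuration does here, so the only anchor is the value of compound 2 itself. The step from compound 2 to compound 3 in this assay is expected to be small, most likely none beyond the scatter, with only a slight lean towards a lower number. Compound 3 is therefore estimated at 84% in this assay, within 68% to 98%. The expected step is a number 4 percentage points lower from compound 2 to compound 3 (within the scatter).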

Compound 3, a percentage reported as activity, at one concentration (the size of the read-out at that concentration, not a potency): 88%
For compound 3 the middle estimate is 4 percentage points below the measured one; the measured number falls inside the stated range.
By their numbers in this assay, from the lowest: compound 1; then compounds 2 and 3 (each within the scatter of the next).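

In this assay the mirrored stereocentre at the saturated chain carbon gives no change at the digits printed from compound 2 to compound 3 (within the scatter), so at this position, with tert-butyl on the aromatic carbon, drawing the centre R or S does not separate the two compounds. This reading of the stereocentre is a direct one, and it rests on a single point: the fact that compounds 2 and 3 differ only in the configuration as drawn. A comparison in one place also becomes possible for the other end of the molecule, where tert-butyl in place of propyl on an aromatic carbon gives a number 12 percentage points higher from compound 1 to compound 3 (beyond the scatter), and of these two changes only this one lies beyond the scatter.

Going by these compounds, it stays open whether the stereocentre is equally without effect with propyl on the aromatic carbon. On these data alone, it also stays open how the number responds there to a longer chain or a carboxylic acid.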